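The source may report more compounds than this note shows. Statements on the series, on what has been measured and on what is new or still open speak of the compounds shown alone.

For the measured compounds named here, in a functional assay on SGC-7901 cells (Homo sapiens) for antiproliferative activity, read by MTT assay, with a stated time of 72 h (on this read-out lower numbers stand for stronger inhibition and higher numbers for weaker inhibition), compound 1 `COc1ccc(-c2c(-c3cc(OC)c(OC)c(OC)c3)ssc2=S)cc1` gives 2350 nM, while compound 2 `COc1ccc(-c2c(-c3cc(OC)c(OC)c(OC)c3)ssc2=S)cc1[N+](=O)[O-]`, which adds a nitro to the same core, gives 44700 nM, the higher of the two numbers measured so far. The next structure is compound 3 `COc1ccc(-c2c(-c3cc(OC)c(OC)c(OC)c3)ssc2=S)cc1N`, which differs from compound 2 by amino in place of nitro on an aromatic carbon, ortho to a methoxy group. Going by the values given here, one measured step bears on this carbon: nitro in place of hydrogen gave a 19-fold higher number from compound 1 to compound 2 (1.28 log units; beyond the scatter), a large step beyond the scatter. Among the compounds with values here, no measured compound carries an amino, so that step shows only how far a change at this carbon has moved the number. The expectation therefore leans on compound 1 at 2350 nM, which has no nitro. A large step to a lower number in this assay is expected, estimated as a 15-fold lower number from compound 2 to compound 3 (1.17 log units; beyond the scatter). For compound 3 the estimated value is 3000 nM, with an expected range from 500 nM to 18000 nM.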

Compound 3, half-maximal inhibitory concentration: 2620 nM
The estimate for compound 3 lay 1.1-fold (0.06 log units) above the measured number; the measured number falls inside the stated range.
By their numbers in this assay, from the lowest: compounds 1 and 3 (each within the scatter of the next); then compound 2.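

In this assay the change from nitro to amino gives a 17-fold lower number from compound 2 to compound 3 (1.23 log units; beyond the scatter) and so undoes the large loss seen with nitro on this carbon, ortho to a methoxy group. Against the parent with hydrogen at this carbon, the amino gives a 1.1-fold higher number from compound 1 to compound 3 (0.05 log units; within the scatter) and this step stays within the scatter, so this carbon carries an amino with no measurable change in this assay, and the large effect seen so far at this position goes with the nitro alone. Nothing available explains why the nitro and the amino part so far.

As far as these compounds go, it remains open whether a hydroxyl, an acetamide or a dimethylamino group on this carbon would stay level with compound 1 or would shift the number as the nitro did. From the compounds shown here alone, the effect of an amino on other carbons of this ring also remains open.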